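The source may hold more compounds than are shown below. What is called first, only, known or untested is meant among the compounds shown, and "the series" means these compounds.

The measured compounds:
- Compound 1, `COc1ccc(-n2c(SCc3ccccc3)nnc2-c2cc(OC)c(OC)c(OC)c2)cc1`. In a functional assay on HepG2 cells (Homo sapiens) for inhibition, read by MTT assay, with a stated time of 48 h (on this read-out lower numbers stand for stronger inhibition and higher numbers for weaker inhibition), compound 1 gives > 60000 nM, which is a limit of the assay rather than a number.
- Compound 2, `COc1ccc(CSc2nnc(-c3cc(OC)c(OC)c(OC)c3)n2-c2ccc(OC)cc2)cc1`. In this assay compound 2 gives 41100 nM.
- Compound 3, `COc1cc(-c2nnc(SCC(=O)c3ccccc3)n2-c2ccc(N(C)C)cc2)cc(OC)c1OC`. In this assay compound 3 gives 18900 nM.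

From compound 1 to compound 2 the structural change is methoxy in place of hydrogen on an aromatic carbon, and it brought an at least 1.4-fold lower number from compound 1 to compound 2 (0.16 log units; that floor lies within the scatter). Compound 4, `COc1ccc(C(=O)CSc2nnc(-c3cc(OC)c(OC)c(OC)c3)n2-c2ccc(N(C)C)cc2)cc1`, has not yet been measured; it carries the same change relative to compound 3: methoxy in place of hydrogen on an aromatic carbon. The two cores differ as well, but that difference is not broken down here. Because the earlier step was an at least 1.4-fold lower number from compound 1 to compound 2 (0.16 log units; that floor lies within the scatter), only a small shift is expected in this assay, namely a 1.5-fold lower number from compound 3 to compound 4 (0.16 log units; within the scatter). Compound 4 is therefore estimated at 13000 nM, most likely falling between 5000 nM and 35000 nM.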

Compound 4, half-maximal inhibitory concentration: 18800 nM
Beside the measured number, compound 4's estimate is 1.4-fold (0.16 log units) below it, within the range that was stated.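

In this assay, putting methoxy in place of hydrogen, which turns the benzoyl group into (4-methoxyphenyl)carbonyl, brought a 1.0-fold lower number from compound 3 to compound 4 (0.00 log units; within the scatter), so on this core the change has no effect that stands out from the scatter. Compound 1 gives > 60000 nM, which is a limit of the assay and not a number. The comparison therefore shows neither that the change carries over from one core to the other nor that it fails to: the same change on two cores in this assay, an at least 1.4-fold lower number (0.16 log units; that floor lies within the scatter) from compound 1 to compound 2 and a 1.0-fold lower number (0.00 log units; within the scatter) from compound 3 to compound 4; the limit leaves it open whether they differ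

As far as these compounds go, whether an amine, a carboxylic acid or a chlorine atom at this same place would shift the number stays open. Also open, from the compounds shown here alone, is how the methoxy change behaves on a pair of cores where both starting values are true numbers.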